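This account rests on a few compounds, and the source may have more. Where it says the series, first, only, none or still open, it means among the compounds named here.

Compound 1 `CCCc1cc2c(cc1O)C(C)(C)C(CCSc1ccccn1)O2`: 44 nM
Compound 2 `C=CCc1cc2c(cc1O)CC(CCc1ccccc1)O2`: 17 nM
Compound 3 `O=C(O)c1ccc(OCCCc2cc3c(cc2O)CC(CCc2ccccc2)O3)cc1`: 44 nM

In an assay for inhibition of Polyunsaturated fatty acid 5-lipoxygenase (Rattus norvegicus) (on this read-out lower numbers stand for stronger inhibition and higher numbers for weaker inhibition), compound 3 gives 44 nM, level with compound 1 within the scatter; together the two stand at the highest number of the three, while compound 2 sits at a number beyond the scatter lower than either and so is the strongest of the measured set. Compound 4 `Oc1cc2c(cc1CCCSc1nc3ccccc3s1)OC(CCc1ccccc1)C2` carries (1,3-benzothiazol-2-yl)sulfanyl in place of 4-carboxyphenoxy on a saturated chain carbon, three bonds along the chain from an aromatic carbon. Within the data shown here, no measured pair shows this exchange, so its effect on this assay is not known; compound 1, bearing a different sulfanyl-linked aromatic on its chain, gives 44 nM, which is level with compound 3. Compound 4 is therefore expected to stay close, with a 1.3-fold lower number from compound 3 to compound 4 (0.10 log units; within the scatter) at most a shift within the scatter. The estimate for compound 4 is 35 nM, ranging from 10 nM to 120 nM.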

Compound 4, half-maximal inhibitory concentration: 45 nM
The estimate for compound 4 lay 1.3-fold (0.11 log units) below the measured number; the range from low to high includes it.
By their numbers in this assay, from the lowest: compound 2; then compounds 1, 3 and 4 (each within the scatter of the next).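

In this assay, putting (1,3-benzothiazol-2-yl)sulfanyl in place of 4-carboxyphenoxy on a saturated chain carbon, three bonds along the chain from an aromatic carbon, gives a 1.0-fold higher number from compound 3 to compound 4 (0.01 log units; within the scatter) and leaves the read-out unmoved. This place therefore accepts two quite different groups of the same heavy-atom count, one with a carboxylic acid and one with sulfur and nitrogen, without a change beyond the scatter. Nothing available explains why the two groups read alike. Still open, as far as these compounds go, is how a smaller group at this place, such as a plain phenoxy or an amine, would read. Also open, from the compounds shown here alone, is whether a longer chain would change the result.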